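This account rests on a few compounds, and the source may have more. Where it says the series, first, only, none or still open, it means among the compounds named here.

Compound 1 `O=C(O)c1cn(Cc2ccc(-n3cccn3)cc2)c2cc(NC[C@@H]3CCNC3)c(F)cc2c1=O` and compound 2 `COc1c(N2CC[C@@H](C(N)=O)C2)c(F)cc2c(=O)c(C(=O)O)cn(Cc3ccc(-c4ccccc4)cc3)c12` share a core and are the two measured points here. In an assay on isolated protein for inhibition of DNA topoisomerase 1 (Homo sapiens), with a stated time of 15 min, tested at 200 uM (on this read-out lower numbers stand for less inhibition and higher numbers for more inhibition at the one concentration tested (going by the name of the read-out)), compound 1 gives 10%, and in this assay compound 2 gives 10%, so compound 2 stands level with compound 1 at the digits shown, within the usual scatter. Among the compounds with values here, no step between measured compounds that differ in one place is available. Compound 3 `CNCCCCNc1c(F)cc2c(=O)c(C(=O)O)cn(Cc3ccc(-c4ccccc4)cc3)c2c1OC` differs from compound 2 in one place: (4-(methylamino)butyl)amino in place of 3-carbamoylpyrrolidin-1-yl on an aromatic carbon. With both measured values at the same low level, the step to compound 3 is expected to stay within the scatter, a number 2 percentage points higher from compound 2 to compound 3 (within the scatter). Compound 3 is estimated at 12%, with a range from 0% to 30%.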

Compound 3, a percentage reported as inhibition, at one concentration (the size of the read-out at that concentration, not a potency): 10%
Beside the measured number, compound 3's estimate is 2 percentage points above it, within the range that was stated.
By their numbers in this assay, from the lowest: compounds 1, 2 and 3 (each within the scatter of the next).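

Putting (4-(methylamino)butyl)amino in place of 3-carbamoylpyrrolidin-1-yl on this aromatic carbon brings no change at the digits printed from compound 2 to compound 3 (within the scatter) in this assay. Within the data shown here, this is the first one-place comparison, and it shows that, at this position, exchanging a five-membered ring carrying an amide for an open chain with no ring leaves the read-out where it was. Nothing available gives a reason for this result.

On these data alone, whether a piperazine ring or a shorter chain ending in a primary amine at this position would give a different reading stays open.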